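Dropping the hydroxyl from the threonine side chain

The source may report more compounds than this note shows. Statements on the series, on what has been measured and on what is new or still open speak of the compounds shown alone.

Measured compounds:
- compound 1 `O=C(CN(c1nc(Cl)nc2[nH]cnc12)C1CC1)N[C@@H](CO)C(=O)O`: 18.8%
- compound 2 `O=C(O)CNC(=O)CN(c1nc(Cl)nc2[nH]cnc12)C1CC1`: 9.08%
- compound 3 `C[C@@H](O)[C@H](NC(=O)CN(c1nc(Cl)nc2[nH]cnc12)C1CC1)C(=O)O`: 24%

These three share one core and differ only in the amino acid attached through the amide. In a functional assay on the whole organism (Tail, strain ICR) with Mus musculus as the target, in the tail flick test, with a stated time of 150 min, at a dose of 25 umol/kg by the oral route (a lower number here means a weaker effect, a higher number a stronger effect of the compound at the dose given), compound 3 gives the largest of the three numbers, but the step of a number 5.2 percentage points higher from compound 1 to compound 3 (within the scatter) is within the scatter, while the step of a number 14.9 percentage points higher from compound 2 to compound 3 (beyond the scatter) is beyond it, so compound 3 is clearly separated only from compound 2.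

Compound 4 `C[C@H](NC(=O)CN(c1nc(Cl)nc2[nH]cnc12)C1CC1)C(=O)O` is the next step: methyl in place of 1-hydroxyethyl on a saturated chain carbon bound to an amide-type nitrogen and a carbonyl carbon. Going by the values given here, two measured steps bear on this. The step of a number 9.7 percentage points lower from compound 1 to compound 2 (within the scatter) removed a hydroxyl-bearing group and was within the scatter. The step of a number 14.9 percentage points higher from compound 2 to compound 3 (beyond the scatter) added one and was modest. Compound 4 keeps the methyl of compound 3 but loses the oxygen, so it should sit between compound 2 and compound 3. The expected step of a number 9 percentage points lower from compound 3 to compound 4 (within the scatter) is therefore a modest loss, likely within or just beyond the scatter. Compound 4 is estimated at 15%, with a range of 5% to 27%.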

Compound 4, a percentage reported as activity, at one dose (the size of the read-out at that dose, not a potency): 14.7%
The estimate for compound 4 lay 0.3 percentage points above the measured number, within the range that was stated.
By their numbers in this assay, from the lowest: compounds 2, 4, 1 and 3 (each within the scatter of the next, the first and the last beyond it).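

In this assay, replacing 1-hydroxyethyl with methyl gives a number 9.3 percentage points lower from compound 3 to compound 4 (within the scatter), while a number 5.6 percentage points higher from compound 2 to compound 4 (within the scatter) and a number 4.1 percentage points lower from compound 1 to compound 4 (within the scatter) are also small, so compound 4 cannot be separated from any of the other three. Compound 2 and compound 3 do differ beyond the scatter, yet compound 4 breaks that difference into two steps, neither of which can be read as a real change alone. Methyl in place of hydrogen also gives a matching result in two settings, the hydroxyl-bearing pair and the pair without that hydroxyl: the same change on two cores in this assay, a number 5.2 percentage points higher (within the scatter) from compound 1 to compound 3 and a number 5.6 percentage points higher (within the scatter) from compound 2 to compound 4, 0.4 percentage points apart, within the scatter of two such steps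

The compounds shown leave open how an amine or a longer chain, such as butyl, would read on this saturated chain carbon bound to an amide-type nitrogen and a carbonyl carbon. They also leave open whether any of these small steps would hold at another dose or time.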